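A few compounds are considered here, and "the series" means these few. Any claim that something is new, unique, unknown or untested is made for them only; others in the source may bear on it.

Compound 1 `CCOC(=O)CCCCCOc1cccc(CN(C(=O)c2ccc(-c3ccncc3)cc2)C(C)C)c1`: in an ADME assay on HepG2 cells (Homo sapiens) for cytotoxicity, read by CellTiter-Glo and resazurin assay, with a stated time of 72 h (on this read-out higher numbers stand for an effect only at larger amounts of compound and lower numbers for an effect already at smaller amounts), compound 1 gives > 26000 nM, which is a limit of the measurement and not a number.
Compound 2 `CCOC(=O)CCCCCOc1cccc(CN(C(=O)c2ccc(-c3cccc(OC(C)C)c3)cc2)C(C)C)c1`: compound 2 gives > 26000 nM, again a limit.
Compound 3 `CCOC(=O)CCCCCOc1cccc(CN(C(=O)c2ccc(-c3cccc(OCc4ccccc4)c3)cc2)C(C)C)c1`: compound 3 gives > 26000 nM, also a limit.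

Among the compounds with values here, compound 3 therefore stands at the limit of > 26000 nM in this assay, at which 3 of the 3 values shown sit, where every measured compound of this small set sits; no compound here separates from the others. The step to compound 4 `CCOC(=O)CCCCCOc1cccc(CN(C(=O)c2ccc(-c3cccc(-c4nnc(C)o4)c3)cc2)C(C)C)c1` is 5-methyl-1,3,4-oxadiazol-2-yl in place of benzyloxy on an aromatic carbon. Two measured steps exist, a step that the two limits leave unreadable from compound 1 to compound 2 and a step that the two limits leave unreadable from compound 2 to compound 3, and both are unreadable, since each joins two limits. Within the data shown here, neither replaces a benzyloxy with a 5-methyl-1,3,4-oxadiazol-2-yl, so no measured step bears directly on this change, and the numbers give no ground to expect a reading in either direction beyond the scatter. Compound 4 is estimated to give 40000 nM, with a range from 15000 nM to 150000 nM, most likely reported once more as a limit. The expected step is a step that the limit leaves unreadable from compound 3 to compound 4.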

Compound 4, half-maximal effective concentration: > 26000 nM
Compound 4: a limit, no number; the forecaster's own chance of this, stated with the estimate: 85%; the middle value is on the limit's open side.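

Compound 4 gives > 26000 nM in this assay, which is a limit and not a number. Its steps from compound 1, compound 2 and compound 3 cannot be read, since all four compounds sit together: the limit of > 26000 nM in this assay, at which 4 of the 4 values shown sit. The compounds shown leave open what amount of any of them would produce a half-maximal effect on these cells, and whether their changes matter.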